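Compound 3 to compound 4: a series held at its limit

The source may report more compounds than this note shows. Statements on the series, on what has been measured and on what is new or still open speak of the compounds shown alone.

In a functional assay on B16 cells (Mus musculus) for antiproliferative activity, with a stated time of 72 h (a lower number here means a stronger inhibitor, a higher number a weaker inhibitor), compound 3 (`COc1ccccc1CNc1ncnc2c1ncn2[C@@H]1O[C@H](CO)[C@@H](O)[C@H]1O`) gives > 166000 nM and this is a limit. Compound 1 (`OC[C@H]1O[C@@H](n2cnc3c(NCc4cccc(Br)c4)ncnc32)[C@H](O)[C@@H]1O`) gives > 166000 nM and this too is a limit. Compound 2 (`Cc1ccc(CNc2ncnc3c2ncn3[C@@H]2O[C@H](CO)[C@@H](O)[C@H]2O)cc1`) has the entry "not determined" (no result reported) and adds nothing. Compound 4 (`OC[C@H]1O[C@@H](n2cnc3c(NCc4ccc(F)cc4F)ncnc32)[C@H](O)[C@@H]1O`) carries 2,4-difluorophenyl in place of 2-methoxyphenyl on a saturated chain carbon bound to a nitrogen on an aromatic ring. Within the data shown here, the one measured step that bears on this is a step that the two limits leave unreadable from compound 1 to compound 3 and it offers no size to carry over. Among the measured compounds shown here, the only guide is the limit of > 166000 nM in this assay, at which 2 of the 3 values shown sit, for compound 1 and compound 3. The expected outcome is a number no higher from compound 3 to compound 4 (the limit leaves the size open) with no step beyond the scatter and no direction favoured. Compound 4 is estimated at 166000 nM with an expected range of 70000 nM to 300000 nM and will probably be reported only as a limit.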

Compound 4, half-maximal inhibitory concentration: > 166000 nM
Compound 4: a limit, no number; the forecaster's own chance of this, stated with the estimate: 85%; the middle value sits exactly at the limit.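

No step among compound 1, compound 3 and compound 4 can be read in this assay as each entry is a limit: the limit of > 166000 nM in this assay, at which 3 of the 4 values shown sit.

The compounds shown leave open whether any benzyl group on the shared core gives a measurable number in this assay.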